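A few compounds are considered here, and "the series" means these few. Any claim that something is new, unique, unknown or untested is made for them only; others in the source may bear on it.

Working notes on a small set of chalcone-type compounds built on a shared core, assessed in a functional assay on UACC-257 cells (Homo sapiens) for cytotoxicity, read by sulforhodamine B assay, with a stated time of 48 h, tested at 0.01 uM; a higher number here means a weaker effect of the compound at the concentration tested, a lower number a stronger effect.

Compound 1 `COc1cc(-c2cc(/C=C/C(=O)c3ccc(N)cc3)[nH]n2)cc(OC)c1OC` gives, in this assay, a reading of 94%. Compound 2 `COc1ccc(-c2cc(/C=C/C(=O)c3ccc(OC)c(OC)c3)[nH]n2)cc1` carries different substitution at both ends of the core; in this assay compound 2 gives 92%. The two readings sit within the usual scatter of each other, so the numbers show no separation between compound 1 and compound 2 at this concentration; both indicate little effect at the tested level.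

Compound 3 `COc1cc(-c2cc(/C=C/C(=O)c3ccc(Cl)c(Cl)c3)[nH]n2)cc(OC)c1OC` is the next member and remains to be measured in this assay. It differs from compound 1 in one place: 3,4-dichlorophenyl in place of 4-aminophenyl on a carbonyl carbon. Among the compounds with values here, no pair of measured compounds that differ in exactly one place is available, so the size of this change has no precedent in the set.

Given that both measured readings are close to full activity and show no separation, the step of a number 2 percentage points lower from compound 1 to compound 3 (within the scatter) is expected to stay within the scatter, in no particular direction. For compound 3 the estimate in this assay is 92%, with a range from 80% to 102%.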

Compound 3, a percentage reported as activity, at one concentration (the size of the read-out at that concentration, not a potency): 96%
Beside the measured number, compound 3's estimate is 4 percentage points below it, and the stated range covers the measured number.
By their numbers in this assay, from the lowest: compounds 2, 1 and 3 (each within the scatter of the next).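

In this assay, within the data shown here, the exchange of 4-aminophenyl for 3,4-dichlorophenyl on a carbonyl carbon gives a number 2 percentage points higher from compound 1 to compound 3 (within the scatter) as the first comparison that isolates one place, so this read-out does not separate the two groups at the concentration tested. The exchange removes the hydrogen-bond donor and acceptor counted for 4-aminophenyl and brings in chlorine, yet the reading stays within the scatter, which gives this position no visible sensitivity to the change under these conditions. No measurement at hand points to a cause for this result.

All three compounds show little effect at this level. As far as these compounds go, the flat result may say little about this position under conditions where the compounds act more strongly, and whether the same exchange would separate there remains open. Also open is whether a phenyl ring carrying a carboxylic acid, a morpholine or a longer alkoxy chain on the same carbonyl carbon would give a reading outside the scatter of the compounds shown.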